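This account rests on a few compounds, and the source may have more. Where it says the series, first, only, none or still open, it means among the compounds named here.

Compound 1 `CCCc1cccc(C[C@H](O)/C=C/[C@H]2CSC(=O)N2CCSCCCC(=O)O)c1` is the reference point. In an assay on CHO cells for displacement of a labelled ligand from prostaglandin E2 receptor EP4 subtype (Mus musculus), read by scintillation counting, with a stated time of 60 min (on this read-out higher numbers stand for weaker inhibition and lower numbers for stronger inhibition), compound 1 gives 0.98 nM, the lowest number among the three measured compounds and so the strongest binder of the set. Two relatives share its acid-bearing chain and hydroxyl-bearing arm but carry a different core and a different group on the aromatic ring. Compound 2 `O=C(O)CCCSCCN1C(=O)OC[C@@H]1/C=C/[C@@H](O)Cc1cccc(-c2ccccc2)c1` gives 28 nM, and compound 3 `O=C(O)CCCSCCN1C(=O)OC[C@@H]1/C=C/[C@@H](O)Cc1cccc(C(F)(F)F)c1` gives 2 nM. Within the data shown here, the one step that can be read between them is a 14-fold lower number from compound 2 to compound 3 (1.15 log units; beyond the scatter), which shows how much the group on the aromatic ring can matter.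

Compound 4 `CCc1cccc(C[C@H](O)/C=C/[C@H]2CSC(=O)N2CCSCCCC(=O)O)c1` is the next compound to be measured. It differs from compound 1 in one place: hydrogen in place of methyl on a saturated chain carbon, two bonds along the chain from an aromatic carbon, so the propyl becomes an ethyl. Among the measured compounds shown here, no measured step touches this kind of change; the only measured step concerns an exchange of a whole group on the aromatic ring, not a shortening of a chain. With nothing pointing either way, the expectation is a step of a 1.4-fold higher number from compound 1 to compound 4 (0.15 log units; within the scatter), within the usual scatter. Compound 4 is therefore expected to give about 1.4 nM, between 0.5 nM and 4 nM.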

Compound 4, inhibition constant: 0.88 nM
The estimate for compound 4 lay 1.6-fold (0.20 log units) above the measured number; measured number inside the range.
By their numbers in this assay, from the lowest: compounds 4 and 1 (each within the scatter of the next); then compound 3; then compound 2.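

Cutting 3-propylphenyl back to 3-ethylphenyl gives a 1.1-fold lower number from compound 1 to compound 4 (0.05 log units; within the scatter) in this assay, so on this core the end methyl of the propyl chain can go with no change that stands out from the scatter. Among these compounds, the earlier compounds showed only that exchanging a whole group on the aromatic ring, on a different core, can matter a great deal, as in a 14-fold lower number from compound 2 to compound 3 (1.15 log units; beyond the scatter); this result shows that a small trim of the chain on the ring need not. Nothing at hand explains why the propyl and ethyl compounds read alike.

On these data alone, how far this tolerance reaches remains open: a longer chain such as butyl, a single methyl on the ring, or an amine at the chain end could behave differently. Whether ethyl and propyl would also read alike on the core of compound 3 is open too.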